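From compound 1 to compound 4: a furan-3-yl exchange

The source may report more compounds than this note shows. Statements on the series, on what has been measured and on what is new or still open speak of the compounds shown alone.

Compound 1 `CC1=C(O)/C(=C/[C@H](C)CC/C=C(/C)CC/C=C(/C)CCCC2=CC(O)OC2=O)OC1=O`: > 100 ug/mL (a limit)
Compound 2 `COC(=O)C(C)(O)[C@@](O)(C[C@H](C)CC/C=C(/C)CC/C=C(/C)CCCc1ccoc1)C(=O)OC`: 46 ug/mL
Compound 3 `COC(=O)C(C)(O)[C@](O)(C[C@H](C)CC/C=C(/C)CC/C=C(/C)CCCC1=CCN(CC(=O)O)C1=O)C(=O)OC`: > 100 ug/mL (a limit)

In a functional assay on K562 cells (Homo sapiens) for cytotoxicity, read by MTT assay (a lower number here means that less compound is tolerated, a higher number that more compound is tolerated), compound 1 gives > 100 ug/mL, which is a limit of the assay and not a number. Compound 1 thus stands at the limit of > 100 ug/mL in this assay, at which 2 of the 3 values shown sit. Compound 3 shares that limit, and only compound 2 gives a number.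

Compound 4 `CC1=C(O)/C(=C/[C@H](C)CC/C=C(/C)CC/C=C(/C)CCCc2ccoc2)OC1=O` differs from compound 1 in one place: a group of 5 heavy atoms (4 carbon, 1 oxygen; one five-membered aromatic ring with 1 hetero atom) in place of a group of 7 heavy atoms (4 carbon, 3 oxygen; one five-membered non-aromatic ring with 1 hetero atom), on a saturated chain carbon, three bonds along the chain from a double-bonded chain carbon. Going by the values given here, no measured step shows this change directly, so any expectation is indirect. Among the compounds with values here, compound 2, the only measured compound carrying furan-3-yl, gives 46 ug/mL, so in this assay a downward step beyond the scatter is expected, meaning less compound tolerated. The expected step is an at least 2.0-fold lower number from compound 1 to compound 4 (0.30 log units; that floor lies within the scatter). With so few numbers the expectation is loose, and a result at the limit would not be surprising. The estimated value for compound 4 is 50 ug/mL, with an expected range from 18 ug/mL to 120 ug/mL.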

Compound 4, concentration lethal to 50% of the cells: 62 ug/mL
The estimate for compound 4 lay 1.2-fold (0.09 log units) below the measured number; measured number inside the range.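

In this assay, compound 4 can be set directly against compound 1, from which it differs only in carrying furan-3-yl on the saturated chain carbon, three bonds along the chain from a double-bonded chain carbon. The exchange gives an at least 1.6-fold lower number from compound 1 to compound 4 (0.20 log units; that floor lies within the scatter), so this one change turns a result at the limit into a number. The step can be read only as a floor, because compound 1 stands at a limit and not at a number: the limit of > 100 ug/mL in this assay, at which 2 of the 4 values shown sit.

The compounds shown leave open the true size of this step. They also leave open whether another group at this place, such as a phenyl ring or a primary amine, would likewise give a number rather than a limit.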